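Swapping the thiophene for a hydroxyphenyl on the biaryl core

The compounds below may be only part of what the source reports. "The series", "measured", "known", "first", "only" and "open" are said of these compounds alone.

Measured compounds:
compound 1 `Cc1ccc(-c2ccccc2OC(C)C2=NCCN2)cc1`, 251 nM
compound 2 `CC(Oc1ccccc1-c1ccncc1)C1=NCCN1`, 1450 nM
compound 3 `CC(Oc1ccccc1-c1cccs1)C1=NCCN1`, 72.4 nM

In an assay on CHO cells for displacement of a labelled ligand from Alpha-2C adrenergic receptor (Homo sapiens) (a higher number here means a weaker inhibitor, a lower number a stronger inhibitor), compound 3 gives the lowest number of the three. Compound 1 lies closest to it, at 251 nM, and compound 2 furthest, at 1450 nM, both steps lying beyond the scatter.

Compound 4 `CC(Oc1ccccc1-c1ccc(O)cc1)C1=NCCN1` differs from compound 3 in one place: 4-hydroxyphenyl in place of thiophen-2-yl on an aromatic carbon. The two measured steps that bear on this change both replace the thiophen-2-yl of compound 3 with a six-membered aromatic ring. One gave a 3.5-fold lower number from compound 1 to compound 3 (0.54 log units; beyond the scatter), the other 20-fold lower number from compound 2 to compound 3 (1.30 log units; beyond the scatter). Read in reverse, both say that moving away from thiophen-2-yl towards a six-membered ring raises the number, by a modest to large amount. Going by the values given here, the entering 4-hydroxyphenyl carries one hydrogen-bond donor, which neither of the measured six-membered rings has, so no measured step settles its size exactly.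

Compound 4 is therefore expected to show a higher number than compound 3, with an expected step of a 5.5-fold higher number from compound 3 to compound 4 (0.74 log units; beyond the scatter). The estimate for compound 4 in this assay is 400 nM, with a range from 120 nM to 1500 nM.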

Compound 4, inhibition constant: 331 nM
Estimate against measurement, compound 4: 1.2-fold (0.08 log units) above; the range from low to high includes it.
By their numbers in this assay, from the lowest: compound 3; then compounds 1 and 4 (each within the scatter of the next); then compound 2.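

In this assay the 4-hydroxyphenyl group shows that a six-membered ring carrying a hydrogen-bond donor does not match thiophen-2-yl on this aromatic carbon, with a 4.6-fold higher number from compound 3 to compound 4 (0.66 log units; beyond the scatter). Thiophen-2-yl thus keeps the lowest number against all three six-membered rings shown. Among those rings, hydroxy in place of methyl makes no difference that can be read, with a 1.3-fold higher number from compound 1 to compound 4 (0.12 log units; within the scatter), whereas the carbon-only 4-hydroxyphenyl ring stands clear of the pyridin-4-yl ring, with a 4.4-fold lower number from compound 2 to compound 4 (0.64 log units; beyond the scatter).

Nothing available explains why these groups differ. As far as these compounds go, it remains open whether an amine or a methoxy group in place of the hydroxy would leave the number where compounds 1 and 4 lie, and whether a furan-2-yl ring would come as low as thiophen-2-yl.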